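Benzyl for cyclohexyl on the piperazine-like ring nitrogen

This account rests on a few compounds, and the source may have more. Where it says the series, first, only, none or still open, it means among the compounds named here.

Of the compounds shown here, three sharing one core have been measured in a functional assay on HeLa cells (Homo sapiens) for antiproliferative activity, read by CCK-8 assay, with a stated time of 72 h, tested at 2 uM; a lower number here means a weaker effect, a higher number a stronger effect of the compound at the concentration tested. Compound 1 `Cc1ccc(N2CCN(C(=S)SCc3ccc(C(=O)Nc4ccccc4N)cc3)CC2)cc1` gives 25.3%, compound 2 `CN1CCN(C(=S)SCc2ccc(C(=O)Nc3ccccc3N)cc2)CC1` gives 52.6%, and compound 3 `Nc1ccccc1NC(=O)c1ccc(CSC(=S)N2CCN(C3CCCCC3)CC2)cc1` gives 30.6%. Compound 3 thus holds the second highest of the three numbers; its nearest neighbour is compound 1, and that gap, a number 5.3 percentage points higher from compound 1 to compound 3 (within the scatter), stays within the scatter, whereas the gap to compound 2, a number 22 percentage points lower from compound 2 to compound 3 (beyond the scatter), lies beyond it.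

Compound 4 `Nc1ccccc1NC(=O)c1ccc(CSC(=S)N2CCN(Cc3ccccc3)CC2)cc1` is yet to be measured in this assay. It differs from compound 3 in one place: benzyl in place of cyclohexyl on an amine nitrogen in a ring. Among the measured compounds shown here, two measured steps bear on this change, both at the same ring nitrogen. Replacing 4-methylphenyl with cyclohexyl gave a number 5.3 percentage points higher from compound 1 to compound 3 (within the scatter), a change within the scatter, while replacing methyl with cyclohexyl gave a number 22 percentage points lower from compound 2 to compound 3 (beyond the scatter). Among the three larger groups tried there, the numbers move little, so a shift from cyclohexyl to benzyl is expected to produce no step beyond the scatter, a number 1.4 percentage points higher from compound 3 to compound 4 (within the scatter). Compound 4 is therefore estimated at 32%, with a range from 18% to 48%.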

Compound 4, a percentage reported as inhibition, at one concentration (the size of the read-out at that concentration, not a potency): 20.6%
Compound 4: the middle estimate sits 11.4 percentage points above what was measured; the measured number falls inside the stated range.
By their numbers in this assay, from the lowest: compounds 4, 1 and 3 (each within the scatter of the next); then compound 2.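

With benzyl, three groups that each carry a six-membered ring have now been placed on this ring nitrogen, and the numbers in this assay do not separate them: the change gives a number 10 percentage points lower from compound 3 to compound 4 (within the scatter) and also a number 4.7 percentage points lower from compound 1 to compound 4 (within the scatter). Set against methyl, the same group gives a number 32 percentage points lower from compound 2 to compound 4 (beyond the scatter), so compound 2 now stands beyond the scatter from all three compounds carrying such a ring. A carbon chain unit placed before an aromatic ring therefore did not bring back the number seen with methyl, whether the comparison is with 4-methylphenyl or with cyclohexyl.

No measured evidence explains this result. The compounds shown leave open how ethyl, a propyl chain or a plain hydrogen on this nitrogen would read, and whether a hydroxyethyl chain would stay with methyl or fall with the ring-bearing groups.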